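Swapping the Fluorophenyl Amide for a Methylcyclohexyl Amide

The compounds below may be only part of what the source reports. "The series", "measured", "known", "first", "only" and "open" are said of these compounds alone.

Compound 1, `O=C(/N=C1\NC2(CCCCO2)CCS1)c1cccc(C(F)(F)F)c1`: in a functional assay on the whole organism (strain CF-1) with Mus musculus as the target, in the writhing test, with a stated time of 15 min (a higher number here means that more compound is needed for the effect, a lower number that less compound is needed), compound 1 gives > 200 mg/kg, which is a limit of the assay and not a number.
Compound 2, `O=C(/N=C1\NC2(CCCCO2)CCS1)c1cccc(F)c1`: in this assay compound 2 gives 9.2 mg/kg.

Among the compounds with values here, compound 2 thus holds the only number in this assay among the measured pair; the other entry is a limit. Within the data shown here, the one measured step, an at least 21-fold lower number from compound 1 to compound 2 (1.33 log units; beyond the scatter), sits on the aromatic ring attached to the carbonyl of the shared core, and it shows that the read-out in this assay can move a long way when the group on that carbonyl is altered.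

Compound 3, `CC1(C(=O)/N=C2\NC3(CCCCO3)CCS2)CCCCC1`, differs from compound 2 by 1-methylcyclohexyl in place of 3-fluorophenyl on a carbonyl carbon. Among the measured compounds shown here, no measured step replaces the aromatic ring with a non-aromatic one, so the measured step bears on this change only indirectly. The large measured step, together with the limit for compound 1, suggests the group on the carbonyl matters, and a loss of some size seems the more likely outcome. Compound 3 is therefore expected to give about 30 mg/kg in this assay, with a range from 8 mg/kg to 150 mg/kg. The expected step from compound 2 to compound 3 is a 3.3-fold higher number from compound 2 to compound 3 (0.51 log units; beyond the scatter).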

Compound 3, dose for half-maximal effect: > 200 mg/kg
Compound 3 was reported as a limit (the forecaster's own chance of this, stated with the estimate: 25%); at least 6.6-fold (0.82 log units) between middle value and limit.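

In this assay compound 3 gives > 200 mg/kg, which is a limit of the assay and not a number. Replacing the aromatic ring gives an at least 21-fold higher number from compound 2 to compound 3 (1.33 log units; beyond the scatter), so on a carbonyl carbon whose other neighbours are an amide-type nitrogen, the change of a whole ring can matter as much as the change of a group on the ring, even though 3-fluorophenyl and 1-methylcyclohexyl have the same count of heavy atoms. Compound 2 is now the only one of the three with a number, while the other two end at the same limit: the limit of > 200 mg/kg in this assay, at which 2 of the 3 values shown sit.

How far compound 1 and compound 3 lie from that limit cannot be read, so the two cannot be ordered against each other. On these data alone, what a plain cyclohexyl, an unsubstituted phenyl or a phenyl carrying an amine would give on this carbonyl stays open, and with it whether the loss of the aromatic ring, the methyl on the new ring or both together lie behind this step.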